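Fluoro on the phenylsulfonyl group of compound 2

A few compounds are considered here, and "the series" means these few. Any claim that something is new, unique, unknown or untested is made for them only; others in the source may bear on it.

Measured so far in a functional assay on HepG2 cells (Homo sapiens) for cytotoxicity, read by MTT assay, with a stated time of 24 h; on this read-out lower numbers stand for stronger inhibition and higher numbers for weaker inhibition:
- compound 1 `CN1C/C(=C\c2ccncc2)C(=O)/C(=C/c2ccccc2F)C1` gives 4600 nM
- compound 2 `O=C1/C(=C/c2cccnc2)CN(S(=O)(=O)c2ccccc2)C/C1=C\c1ccccc1F` gives 8210 nM

Compound 2, at 8210 nM, lies within the scatter of compound 1, so these two numbers do not separate. The next compound, compound 3 `O=C1/C(=C/c2cccnc2)CN(S(=O)(=O)c2ccc(F)cc2)C/C1=C\c1ccccc1F`, differs from compound 2 in one place: fluoro in place of hydrogen on an aromatic carbon, turning phenylsulfonyl to (4-fluorophenyl)sulfonyl. Among the measured compounds shown here, no measured pair in this set shows what such a change does, so the expectation in this assay is no step beyond the scatter, in either direction, and it rests on compound 2 at 8210 nM alone. This amounts to an estimated 1.2-fold lower number from compound 2 to compound 3 (0.07 log units; within the scatter) within that scatter. Compound 3 is expected at 7000 nM, with an estimated range of 3000 nM to 15000 nM for the measurement.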

Compound 3, half-maximal inhibitory concentration: 15600 nM
Beside the measured number, compound 3's estimate is 2.2-fold (0.35 log units) below it, and the stated range ends below it.
By their numbers in this assay, from the lowest: compounds 1, 2 and 3 (each within the scatter of the next, the first and the last beyond it).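

In this assay, among the compounds shown here, the first pair for this change gives fluoro in place of hydrogen on an aromatic carbon, para to a large group, as a step that stays inside the usual variation (a 1.9-fold higher number from compound 2 to compound 3 (0.28 log units; within the scatter)). Phenylsulfonyl and (4-fluorophenyl)sulfonyl therefore do not separate on this read-out, and this position accepts fluoro without a step beyond the scatter in this one pair. Nothing available bears on the reason for this outcome.

On these data alone, whether an amine, a carboxylic acid or a longer chain at this position on the phenylsulfonyl group would give a step beyond the scatter remains open. Also open, as far as these compounds go, is whether fluoro behaves the same way at other positions on that ring, since a single pair gives no trend for the series.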